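The source may hold more compounds than are shown below. What is called first, only, known or untested is meant among the compounds shown, and "the series" means these compounds.

Compound 1 `C=C(Br)C(=O)Nc1ccc(C(=O)/C=C/c2ccc(OC)c(OC)c2)cc1`: 1800 nM
Compound 2 `C=C(Br)C(=O)Nc1ccc(C(=O)/C=C/c2cc(OC)cc(OC)c2)cc1`: 1500 nM

These two compounds were tested in a functional assay on MOLT-4 cells (Homo sapiens) for antiproliferative activity, with a stated time of 48 h; a higher number here means a weaker inhibitor, a lower number a stronger inhibitor. Compound 2 gives 1500 nM and compound 1 gives 1800 nM. Among the compounds with values here, the two numbers lie within the usual scatter of each other, so compound 2 cannot be ranked against its only neighbour.

Compound 3 `C=C(Br)C(=O)Nc1ccc(C(=O)/C=C/c2cc(OC)c(OC)c(OC)c2)cc1` is built from compound 2 by one change: methoxy in place of hydrogen on an aromatic carbon. The new methoxy sits in place of a hydrogen on an aromatic carbon, ortho to two methoxy groups and para to a large group.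

Within the data shown here, no measured pair here differs in just one place, so this expectation has no measured step behind it and remains uncertain. A modest move towards a lower number seems most likely, and it may not clear the scatter by much. The expected change is a 1.7-fold lower number from compound 2 to compound 3 (0.22 log units; within the scatter). For compound 3 the estimate is 900 nM, with an expected range from 300 nM to 2500 nM.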

Compound 3, half-maximal inhibitory concentration: 280 nM
Compound 3: middle estimate off by 3.2-fold (0.51 log units), on the high side; measured number outside the range, below it.
By their numbers in this assay, from the lowest: compound 3; then compounds 2 and 1 (each within the scatter of the next).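

The two earlier compounds, each with two methoxy groups, could not be told apart, so they said nothing about how much the methoxy pattern on this ring matters. In this assay, a methoxy in place of hydrogen, ortho to two methoxy groups and para to a large group, gives a 5.4-fold lower number from compound 2 to compound 3 (0.73 log units; beyond the scatter), a step beyond the scatter, and the same kind of change gives a 6.4-fold lower number from compound 1 to compound 3 (0.81 log units; beyond the scatter), so both routes to the third methoxy end at a clearly lower number. Nothing shown here explains why this change helps.

On these data alone, it remains open whether methoxy itself is needed at this place, or whether a hydroxyl group, a chlorine atom or a longer ethoxy chain would give a similar number. As far as these compounds go, it is also open whether the same step would appear on a different core.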